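Working notes: from compound 2 to compound 4

The compounds below may be only part of what the source reports. "The series", "measured", "known", "first", "only" and "open" are said of these compounds alone.

Measured in an ADME assay on HUVEC cells (Homo sapiens) for cytotoxicity, read by MTT assay, with a stated time of 72 h; a higher number here means a weaker inhibitor, a lower number a stronger inhibitor:
- compound 1 `COc1cc(-c2nccn2S(=O)(=O)c2ccccc2)cc(OC)c1OC`: "not determined" (no result reported)
- compound 2 `COc1ccc(-n2ccnc2-c2cc(OC)c(OC)c(OC)c2)cc1[N+](=O)[O-]`: "not determined" (no result reported)
- compound 3 `COc1cc(-c2nccn2-c2ccc3[nH]ccc3c2)cc(OC)c1OC`: 46700 nM

Compound 2 has no place on the numeric scale, since its entry in this assay reads "not determined" (no result reported). Among the measured compounds shown here, compound 1 is in the same position, so the series offers a single number, and no step between measured compounds exists.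

Compound 4 `COc1cc(-c2nccn2-c2cccc([N+](=O)[O-])c2)cc(OC)c1OC` is the next to be read. The structural change hydrogen in place of methoxy on an aromatic carbon is hydrogen in place of methoxy on an aromatic carbon, ortho to a nitro group and para to a large group.

No step beyond the scatter is expected from this change in this assay, in either direction, although compound 2 supplies no number to test that against. For the measured compounds named here, the expectation therefore leans on compound 3 at 46700 nM, the only measured value, and stays wide. For compound 4 the estimated value is 40000 nM, with an expected range from 10000 nM to 100000 nM.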

Compound 4, half-maximal inhibitory concentration: > 100000 nM
Compound 4: only a limit was reported; the forecaster's own chance of this, stated with the estimate: 25%; middle value at least 2.5-fold (0.39 log units) from the limit.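

In this assay compound 4 gives > 100000 nM, which is a limit and not a number. Among the compounds shown here, with compound 2 at "not determined" (no result reported), no step between compound 2 and compound 4 can be read. The compounds shown leave open how hydrogen in place of methoxy at this position changes the value in this assay.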